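The source may report more compounds than this note shows. Statements on the series, on what has been measured and on what is new or still open speak of the compounds shown alone.

Measured compounds:
- compound 1, `O=[N+]([O-])c1cccc(CSc2nnc(-c3ccncc3)n2-c2ccccc2)c1`: 18300 nM
- compound 2, `COc1ccc(/C=N/NC(=O)CSc2nnc(-c3ccncc3)n2-c2ccccc2)cc1`: 23700 nM

Both were tested in a functional assay on MCF7 cells (Homo sapiens) for inhibition, read by MTT assay, with a stated time of 48 h; on this read-out lower numbers stand for stronger inhibition and higher numbers for weaker inhibition. In this assay compound 1 gives 18300 nM, and compound 2 gives 23700 nM. The two numbers lie within the usual scatter of repeated measurements of each other, so on the numbers shown the two compounds cannot be told apart; both sit in the weakly inhibiting range.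

Compound 3, `O=C(CSc1nnc(-c2ccncc2)n1-c1ccccc1)N/N=C/c1cc(Br)ccc1O`, has not yet been measured in this assay. It differs from compound 2 in a single place: 5-bromo-2-hydroxyphenyl in place of 4-methoxyphenyl on a carbon with a double bond to nitrogen. The shared core, the sulfur-linked chain and the hydrazone part are unchanged; only the aromatic ring at the far end carries different groups.

Going by the values given here, no measured pair shows what such a swap does on this core, so there is no step to lean on. With compound 2 at 23700 nM, the expected step from compound 2 to compound 3 is a 1.2-fold lower number from compound 2 to compound 3 (0.07 log units; within the scatter), that is, nothing beyond the scatter in either direction. Compound 3 is therefore estimated at 20000 nM, with a likely range from 7000 nM to 60000 nM.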

Compound 3, half-maximal inhibitory concentration: 6460 nM
Compound 3: the middle estimate sits 3.1-fold (0.49 log units) above what was measured; the whole stated range lies above it.
By their numbers in this assay, from the lowest: compound 3; then compounds 1 and 2 (each within the scatter of the next).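

In this assay the group on the carbon with a double bond to nitrogen proves able to shift the result: swapping 4-methoxyphenyl for 5-bromo-2-hydroxyphenyl gives a 3.7-fold lower number from compound 2 to compound 3 (0.56 log units; beyond the scatter) and so moves the compound towards stronger inhibition, a change that the two earlier values, lying within the scatter of each other, could not reveal. The two groups have the same number of heavy atoms and both contain one six-membered aromatic ring of carbon only, but the entering group brings bromine and a hydrogen-bond donor, while the leaving group has neither. Nothing available explains why this swap lowers the number.

The swap changes several features at once, so the compounds shown cannot separate the part played by the bromine from that of the hydroxyl group, and a phenyl ring carrying only one of the two would be needed to pull them apart. Also open, from the compounds shown here alone, is how other groups at this place would behave, such as a phenyl ring bearing an amine or a carboxylic acid.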